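This account rests on a few compounds, and the source may have more. Where it says the series, first, only, none or still open, it means among the compounds named here.

Measured so far in a functional assay on MDA-MB-435 cells (Homo sapiens); a higher number here means a weaker inhibitor of growth, a lower number a stronger inhibitor of growth:
Compound 1, `Cc1ccnc2nc(-c3ccc(F)cc3)cc(O)c12`, gives 2880 nM.
Compound 2, `COc1cccc(-c2cc(O)c3c(C)cc(C)nc3n2)c1`, gives < 10 nM, which is a limit of this assay and not a number.
Compound 3, `Cc1cnc2nc(-c3ccc(Cl)cc3)cc(O)c2c1`, gives 603 nM.

Of the two numbers, compound 3 holds the lower one; compound 1 sits clearly higher, beyond the scatter, so compound 3 is the stronger inhibitor of growth of the pair. Compound 2 contributes only a limit.

Compound 4, `COc1ccc(-c2cc(O)c3cc(C)cnc3n2)cc1`, differs from compound 3 by methoxy in place of chloro on an aromatic carbon. Among the compounds with values here, no measured pair shows this exchange, so the direction is open; the expectation is a small step downward, at the edge of the scatter. Compound 4 is expected to give 400 nM in this assay, with a range of 100 nM to 1600 nM, an estimated step of a 1.5-fold lower number from compound 3 to compound 4 (0.18 log units; within the scatter).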

Compound 4, concentration for 50% growth inhibition: 1820 nM
Beside the measured number, compound 4's estimate is 4.6-fold (0.66 log units) below it, and the stated range ends below it.
By their numbers in this assay, from the lowest: compound 3; then compounds 4 and 1 (each within the scatter of the next). At a limit, below all of these: compound 2.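

In this assay methoxy in place of chloro, on an aromatic carbon para to a large group, gives a 3.0-fold higher number from compound 3 to compound 4 (0.48 log units; beyond the scatter) in the direction of weaker inhibition of growth. Within the data shown here, this is the first single-place step, and it places chloro ahead of methoxy at this position, for this pair only. Nothing shown gives a cause for this step.

As far as these compounds go, whether an amine or a carboxylic acid at this position would match chloro remains open. Also open, from the compounds shown here alone, is whether the exchange runs the same way on the cores of the other compounds.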